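Furyl substitution on the oxadiazole ketone

The source may report more compounds than this note shows. Statements on the series, on what has been measured and on what is new or still open speak of the compounds shown alone.

Compound 1 `O=Cc1coc(C(=O)CCCCCCc2ccccc2)n1` gives 1510 nM in an assay on HEK-293T cells for inhibition of diacylglycerol lipase-alpha (Homo sapiens), read by colorimetric assay; a higher number here means a weaker inhibitor, a lower number a stronger inhibitor. Compound 2 `O=C(CCCCCCc1ccccc1)c1ncno1` reaches only a limit in this assay, namely > 10000 nM. That value is the limit of > 10000 nM in this assay, at which 1 of the 2 values shown sits. The step of an at least 6.6-fold higher number from compound 1 to compound 2 (0.82 log units; beyond the scatter) therefore shows that exchanging the heterocycle on the carbonyl carbon weakens inhibition, at least modestly. Compound 3 `O=C(CCCCCCc1ccccc1)c1nc(-c2ccco2)no1` differs from compound 2 by furan-2-yl in place of hydrogen on an aromatic carbon. Among the compounds with values here, no measured step touches this position, so the direction rests on that single series observation alone. Compound 3 is estimated at 3000 nM, within a range of 500 nM to 10000 nM. The step of an at least 3.3-fold lower number from compound 2 to compound 3 (0.52 log units; beyond the scatter) is expected as a gain of uncertain size.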

Compound 3, half-maximal inhibitory concentration: 933 nM
Compound 3: the middle estimate sits 3.2-fold (0.51 log units) above what was measured; the measured number falls inside the stated range.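

Within the data shown here, the position between the two ring nitrogen atoms on the oxadiazole accepts a substituent, which the earlier compounds could not show. In this assay, furan-2-yl in place of hydrogen gives an at least 10-fold lower number from compound 2 to compound 3 (1.03 log units; beyond the scatter), a large gain in inhibition. Compound 2 stands at a limit of the assay, so the true size of this step stays open: the limit of > 10000 nM in this assay, at which 1 of the 3 values shown sits.

The compounds shown leave open whether the gain is specific to furan-2-yl or would also appear with a phenyl ring, a methyl group or an amine on this carbon.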